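Notes on a heptyl-for-hydrogen step in cell viability

The compounds below may be only part of what the source reports. "The series", "measured", "known", "first", "only" and "open" are said of these compounds alone.

Three measured compounds have been run in an ADME assay on J774 cells (Mus musculus) for cytotoxicity, read by MTT assay, with a stated time of 24 h, tested at 30 uM; on this read-out lower numbers stand for a stronger effect and higher numbers for a weaker effect at the one concentration tested:

Compound 1 `CCCCCCCCCCCO[C@@H]1[C@@H](N)[C@@H](O[C@H]2[C@H](O)[C@@H](OCCCCCCC)[C@H](N)C[C@@H]2N)O[C@H](CN)[C@H]1O`: 39.1%
Compound 2 `CCCCCCCCCCCO[C@@H]1[C@@H](O)[C@H](O[C@H]2O[C@H](CN)[C@@H](O)[C@H](O)[C@H]2N)[C@@H](N)C[C@H]1N`: 83.4%
Compound 3 `CCCCCCCCCCCO[C@@H]1[C@@H](N)[C@@H](O[C@H]2[C@H](O)[C@@H](O)[C@H](N)C[C@@H]2N)O[C@H](CN)[C@H]1O`: 77.1%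

One single-point change is characterised. From compound 3 to compound 1 the change is heptyl in place of hydrogen on an oxygen on a saturated carbon, and in this assay it gives a number 38 percentage points lower from compound 3 to compound 1 (beyond the scatter). Compound 2 and compound 3 are built from the same atoms joined differently; the difference between the two cores is not broken down here, and their two values lie within the scatter of each other, so nothing is read into their gap.

Compound 4 `CCCCCCCCCCCO[C@@H]1[C@@H](O)[C@H](O[C@H]2O[C@H](CN)[C@@H](O)[C@H](OCCCCCCC)[C@H]2N)[C@@H](N)C[C@H]1N` is not yet measured. It is obtained from compound 2 by heptyl in place of hydrogen on an oxygen on a saturated carbon, the same change as from compound 3 to compound 1, at a place described in identical terms. Given that only one instance of this change is measured, the expectation rests on the step from compound 3 to compound 1 alone: compound 4 is expected to show a number 36.4 percentage points lower from compound 2 to compound 4 (beyond the scatter), a step of comparable size to a number 38 percentage points lower from compound 3 to compound 1 (beyond the scatter). Compound 4 is therefore estimated at 47%, with a range from 30% to 68%.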

Compound 4, a percentage reported as activity, at one concentration (the size of the read-out at that concentration, not a potency): 38.8%
For compound 4 the middle estimate is 8.2 percentage points above the measured one; the range from low to high includes it.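

In this assay the change from hydroxy to heptyloxy gives a number 44.6 percentage points lower from compound 2 to compound 4 (beyond the scatter). Set beside the earlier step, the change carries from one core to the other with its size held: the same change on two cores in this assay, a number 38 percentage points lower (beyond the scatter) from compound 3 to compound 1 and a number 44.6 percentage points lower (beyond the scatter) from compound 2 to compound 4, 6.6 percentage points apart, within the scatter of two such steps

This shows agreement between these two cores only, for a single chain at a single tested concentration; two instances do not establish that the step would hold on a further core, and they say nothing about why the number falls.

The compounds shown leave open whether a shorter chain such as propyl, a longer chain such as decyl, or a heptyl chain ending in an amine or a carboxylic acid would give a step of similar size at this oxygen. Also open, from the compounds shown here alone, is whether the same heptyl change on a different hydroxy of these cores would give a comparable step, and how the read-out would behave at other concentrations.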